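Series notes: cyclopropyl-amino core, amino acid side chain variation

The compounds below may be only part of what the source reports. "The series", "measured", "known", "first", "only" and "open" are said of these compounds alone.

Two compounds of the series carry a measurement. Compound 1 `O=C(CN(c1nc(Cl)nc2[nH]cnc12)C1CC1)N[C@@H](CO)C(=O)O` gives 43.9% in a functional assay on the whole organism (Tail, strain ICR) with Mus musculus as the target, in the tail flick test, with a stated time of 90 min, at a dose of 25 umol/kg by the oral route; on this read-out lower numbers stand for a weaker effect and higher numbers for a stronger effect at the one dose given. Compound 2 `C[C@@H](O)[C@H](NC(=O)CN(c1nc(Cl)nc2[nH]cnc12)C1CC1)C(=O)O` gives 35.9% in this assay. The step of a number 8 percentage points lower from compound 1 to compound 2 (within the scatter) is within the scatter, so the two numbers are not distinguished, and compound 2 cannot be placed apart from compound 1 on these data.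

The next compound, compound 3 `CC(C)[C@H](NC(=O)CN(c1nc(Cl)nc2[nH]cnc12)C1CC1)C(=O)O`, differs from compound 2 by the change (isopropyl in place of 1-hydroxyethyl on a saturated chain carbon bound to an amide-type nitrogen and a carbonyl carbon). Among the compounds with values here, only one measured step bears on it: a number 8 percentage points lower from compound 1 to compound 2 (within the scatter), which put methyl in place of hydrogen on a saturated chain carbon bound to an oxygen on a saturated carbon, and that step stayed within the scatter. Within the data shown here, no measured step removes the hydroxyl from the side chain, so that part of the change has no precedent. The expectation for this assay is therefore a step of no clear direction beyond the scatter, with wide uncertainty for the unmatched part of the change. Compound 3 is estimated at 35%, in the range 12% to 58%, which would mean an expected step of a number 0.9 percentage points lower from compound 2 to compound 3 (within the scatter).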

Compound 3, a percentage reported as activity, at one dose (the size of the read-out at that dose, not a potency): 30.3%
Beside the measured number, compound 3's estimate is 4.7 percentage points above it, and the stated range covers the measured number.
By their numbers in this assay, from the lowest: compounds 3, 2 and 1 (each within the scatter of the next, the first and the last beyond it).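

In this assay, isopropyl in place of 1-hydroxyethyl on the saturated chain carbon bound to an amide-type nitrogen and a carbonyl carbon gives a number 5.6 percentage points lower from compound 2 to compound 3 (within the scatter), so this pair does not separate the two groups at this place. Isopropyl in place of hydroxymethyl at the same place gives a number 13.6 percentage points lower from compound 1 to compound 3 (beyond the scatter), the only step among the shown compounds that lies beyond the scatter, though it is modest, while compound 2 remains within the scatter of both compound 1 and compound 3. No measurement at hand gives a cause for these numbers.

The shown side chains are limited to hydroxymethyl, 1-hydroxyethyl and isopropyl, so the outcome at this place with a longer chain ending in an amine, or with a benzyl group, remains open. Also open is whether the modest separation of compound 1 from compound 3 would persist at other doses or times in this assay, since the shown data cover one dose and one time.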